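The source may report more compounds than this note shows. Statements on the series, on what has been measured and on what is new or still open speak of the compounds shown alone.

Measured so far:
compound 1 `CC1=NN(C(=O)c2ccc(C)cc2)C(c2ccccc2O)C1`, 11300 nM
compound 2 `O=C(CCl)N1N=C(c2cc3ccccc3oc2=O)CC1c1ccccc1`, 2980 nM

In a functional assay on HepG2 cells (Homo sapiens) for cytotoxicity, read by MTT assay, with a stated time of 48 h (on this read-out lower numbers stand for stronger inhibition and higher numbers for weaker inhibition), compound 2 gives 2980 nM and holds the lowest number of the two; compound 1 gives 11300 nM, a gap beyond the scatter. Compound 3 `O=C(CN1CCC(O)CC1)N1N=C(c2cc3ccccc3oc2=O)CC1c1ccccc1` is not yet measured. It differs from compound 2 in one place: 4-hydroxypiperidin-1-yl in place of chloro on a saturated chain carbon bound to a carbonyl carbon. Within the data shown here, no step between measured compounds shows what this change does. The expectation is a step toward weaker inhibition, a 2.3-fold higher number from compound 2 to compound 3 (0.37 log units; beyond the scatter), modest but likely beyond the scatter. Compound 3 is thus estimated at 7000 nM, with a range from 2500 nM to 20000 nM.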

Compound 3, half-maximal inhibitory concentration: "not active" (no number reported)
The entry for compound 3 holds no number, so the estimate cannot be set against anything.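

Among these compounds, compound 3 is reported as "not active" without a number, so no step from compound 2 to compound 3 can be read. The compounds shown leave open how large the change from chloro to 4-hydroxypiperidin-1-yl is. No evidence bears on this result.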